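Bromine on the phenyl ketone: a repeated change

The compounds below may be only part of what the source reports. "The series", "measured", "known", "first", "only" and "open" are said of these compounds alone.

In a functional assay on MCF7 cells (Homo sapiens) for cytotoxicity, read by MTT assay and propidium iodide staining, with a stated time of 24 h (on this read-out lower numbers stand for stronger inhibition and higher numbers for weaker inhibition), compound 1 `Cc1ccc(-c2nnc(SCC(=O)c3ccccc3)o2)c(O)c1` gives 150 nM and compound 2 `COc1cc(OC)cc(-c2nnc(SCC(=O)c3ccccc3)o2)c1` gives 170 nM; the difference between the two cores is not broken down here. Compound 3 `Cc1ccc(-c2nnc(SCC(=O)c3ccc(Br)cc3)o2)c(O)c1` carries bromo in place of hydrogen on an aromatic carbon relative to compound 1, and in this assay compound 3 gives 2070 nM, so that a 14-fold higher number from compound 1 to compound 3 (1.14 log units; beyond the scatter). Compound 4 `COc1cc(OC)cc(-c2nnc(SCC(=O)c3ccc(Br)cc3)o2)c1` stands to compound 2 as compound 3 stands to compound 1, through (bromo in place of hydrogen on an aromatic carbon), the same change at the same place. Because compound 3 showed a 14-fold higher number from compound 1 to compound 3 (1.14 log units; beyond the scatter), the step from compound 2 to compound 4 in this assay is expected to be of a similar size, a 13-fold higher number from compound 2 to compound 4 (1.11 log units; beyond the scatter), resting only on that one measured pair. Compound 4 is therefore estimated to give 2200 nM, most likely between 700 nM and 7000 nM.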

Compound 4, half-maximal inhibitory concentration: 270 nM
Compound 4: middle estimate off by 8.1-fold (0.91 log units), on the high side; the whole stated range lies above it.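

In this assay, phenyl to 4-bromophenyl on the core of compound 2 gives a 1.6-fold higher number from compound 2 to compound 4 (0.20 log units; within the scatter). The size of the step therefore does not carry over from one core to the other: the same change on two cores in this assay, a 14-fold higher number (1.14 log units; beyond the scatter) from compound 1 to compound 3 and a 1.6-fold higher number (0.20 log units; within the scatter) from compound 2 to compound 4, 8.7-fold (0.94 log units) apart, beyond the scatter of two such steps

This shows that, for these two pairs, the result of the change depends on the core it is made on. It does not show which part of the cores accounts for the gap, and two pairs give no rule for any further core.

The compounds shown leave open whether a chloro group or an amine in place of the bromo would follow the pattern of compound 3 or that of compound 4.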